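Moving the nitro group from compound 3 to compound 4

A few compounds are considered here, and "the series" means these few. Any claim that something is new, unique, unknown or untested is made for them only; others in the source may bear on it.

Compound 1 `O=[N+]([O-])c1ccccc1-n1cc(COc2ccc3ncnc(NCc4ccccc4)c3c2)nn1` gives > 200000 nM in a functional assay on HepG2 cells (Homo sapiens) for cytotoxicity, read by MTT assay (a higher number here means a weaker inhibitor, a lower number a stronger inhibitor), which is a limit of the assay and not a number.
Compound 2 `O=[N+]([O-])c1cccc(-n2cc(COc3ccc4ncnc(NCc5ccccc5)c4c3)nn2)c1` gives 94100 nM.
Compound 3 `CN1CCN(c2ncnc3ccc(OCc4cn(-c5ccccc5[N+](=O)[O-])nn4)cc23)CC1` gives 143000 nM.

Compound 3 sits among the two measured numbers with compound 2 as its nearest neighbour, and the two lie within the scatter of each other, so no order between them can be read. Compound 4 `CN1CCN(c2ncnc3ccc(OCc4cn(-c5cccc([N+](=O)[O-])c5)nn4)cc23)CC1` is the unmeasured partner of compound 3; the change is 3-nitrophenyl in place of 2-nitrophenyl on an aromatic nitrogen. The same change has been measured once, from compound 1 to compound 2, where an at least 2.1-fold lower number from compound 1 to compound 2 (0.32 log units; beyond the scatter); as compound 1 only reached (the limit of > 200000 nM in this assay, at which 1 of the 3 values shown sits), that step is a floor rather than a full number. The other measured step, an at least 1.3-fold lower number from compound 1 to compound 3 (0.14 log units; that floor lies within the scatter), concerns a different change and has a floor inside the scatter. On the strength of the first step a lower number, of at least modest size, is expected for compound 4 in this assay, so that a 2.0-fold lower number from compound 3 to compound 4 (0.31 log units; beyond the scatter) is the estimated step. Compound 4 is therefore estimated at 70000 nM, with a range from 35000 nM to 140000 nM.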

Compound 4, half-maximal inhibitory concentration: > 200000 nM
Compound 4: no number, only a limit; the forecaster's own chance of this, stated with the estimate: 5%; middle value at least 2.8-fold (0.45 log units) from the limit.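

In this assay, 3-nitrophenyl in place of 2-nitrophenyl on the aromatic nitrogen gives an at least 1.3-fold higher number from compound 3 to compound 4 (0.14 log units; that floor lies within the scatter), so the lower number seen on the core of compound 1 does not carry over to the core of compound 3: the same change on two cores in this assay, an at least 2.1-fold lower number (0.32 log units; beyond the scatter) from compound 1 to compound 2 and an at least 1.3-fold higher number (0.14 log units; that floor lies within the scatter) from compound 3 to compound 4, at least 2.9-fold (0.47 log units) apart, beyond the scatter of two such steps

The exchange of benzylamino for 4-methylpiperazin-1-yl also reads differently with the 3-nitrophenyl group in place, giving an at least 2.1-fold higher number from compound 2 to compound 4 (0.32 log units; beyond the scatter), so neither change can be taken alone: the same change on two cores in this assay, an at least 1.3-fold lower number (0.14 log units; that floor lies within the scatter) from compound 1 to compound 3 and an at least 2.1-fold higher number (0.32 log units; beyond the scatter) from compound 2 to compound 4, at least 2.9-fold (0.47 log units) apart, beyond the scatter of two such steps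

Compound 4 stands at a limit and not at a number, so its steps are floors: the limit of > 200000 nM in this assay, at which 2 of the 4 values shown sit.

As far as these compounds go, the full size of the gap between the two cores therefore stays open. Also open, from the compounds shown here alone, is how an amine or a carboxylic acid in place of the nitro group on the phenyl ring would read in this assay on either core.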